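A Methoxy Group at the End of the Chain

The source may hold more compounds than are shown below. What is called first, only, known or untested is meant among the compounds shown, and "the series" means these compounds.

Measured compounds:
compound 1 `CC(C(=O)NCc1ccc(C(C)(C)C)nc1N1CCC(Cc2ccccc2)CC1)c1ccc(NS(C)(=O)=O)c(F)c1`: 0.3 nM
compound 2 `CCCOc1nc(C(C)(C)C)ccc1CNC(=O)C(C)c1ccc(NS(C)(=O)=O)c(F)c1`: 1.7 nM
compound 3 `CCCCOc1nc(C(C)(C)C)ccc1CNC(=O)C(C)c1ccc(NS(C)(=O)=O)c(F)c1`: 0.9 nM

In an assay on cells for antagonist activity at transient receptor potential cation channel subfamily V member 1 (Homo sapiens), read by FLIPR and calcium flux, with a stated time of 6 min (on this read-out higher numbers stand for weaker inhibition and lower numbers for stronger inhibition), compound 3 gives 0.9 nM, the second highest of the three numbers. Compound 2 is its nearest neighbour and lies within the scatter of it, while compound 1 is the furthest and lies beyond the scatter, with the lower number.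

Compound 4 `COCCCOc1nc(C(C)(C)C)ccc1CNC(=O)C(C)c1ccc(NS(C)(=O)=O)c(F)c1` differs from compound 3 by methoxy in place of methyl on a saturated chain carbon, three bonds along the chain from an oxygen on an aromatic ring. For the measured compounds named here, the only measured step at this place is a 1.9-fold lower number from compound 2 to compound 3 (0.28 log units; within the scatter), a change that stayed within the scatter. Going by the values given here, that step added a carbon only; here an oxygen enters in its stead, and no measured step shows what that does. The step from compound 3 to compound 4 is therefore expected to be a 1.3-fold higher number from compound 3 to compound 4 (0.12 log units; within the scatter), small and within the scatter. Compound 4 is estimated at 1.2 nM, in a range from 0.4 nM to 4 nM.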

Compound 4, inhibition constant: 5.6 nM
Estimate against measurement, compound 4: 4.7-fold (0.67 log units) below, and the stated range ends below it.
By their numbers in this assay, from the lowest: compound 1; then compounds 3 and 2 (each within the scatter of the next); then compound 4.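

In this assay the place proved sensitive to oxygen as it had not been to carbon: methoxy in place of methyl gave a 6.2-fold higher number from compound 3 to compound 4 (0.79 log units; beyond the scatter) while the earlier added methyl stayed within the scatter. Methoxy in place of hydrogen gave a 3.3-fold higher number from compound 2 to compound 4 (0.52 log units; beyond the scatter) and so the weaker inhibition holds against the shorter chain as well. Nothing available explains this change. The compounds shown leave open whether a hydroxyl or a dimethylamino group in that place would behave as methoxy does, and whether a longer chain carrying methoxy would do the same.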